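The source may hold more compounds than are shown below. What is called first, only, known or untested is meant among the compounds shown, and "the series" means these compounds.

Measured compounds in a functional assay on NUGC-3 cells (Homo sapiens) for cytotoxicity, read by sulforhodamine B assay, with a stated time of 72 h; a lower number here means a stronger inhibitor of growth, a higher number a weaker inhibitor of growth:
compound 1 `O=C(Nc1ccccc1C(F)(F)F)C1CCc2ccccc2N1` gives 39300 nM;
compound 3 `O=C(Nc1ccccc1O)C1CCc2ccccc2N1` gives 2680 nM.
Compound 2 `O=C(Nc1ccc(O)cc1)C1CCc2ccccc2N1` gives only a limit of the assay, > 100000 nM (the limit of > 100000 nM in this assay, at which 1 of the 3 values shown sits).

Going by the values given here, compound 1 stands at the highest of the two numbers reported; the nearest is compound 3, and the step of a 15-fold lower number from compound 1 to compound 3 (1.17 log units; beyond the scatter) is the only structural step with a measured outcome. That step concerns the aromatic ring of the anilide, not the ring nitrogen of the shared core.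

Compound 4 `CC(=O)N1c2ccccc2CCC1C(=O)Nc1ccccc1C(F)(F)F` differs from compound 1 by acetyl in place of hydrogen on a nitrogen on an aromatic ring in a ring. Among the compounds with values here, no measured pair touches this nitrogen, so the step 1>3 bears on it only indirectly: it shows that changes at the anilide ring can move this assay strongly, but says nothing about acylation of the core nitrogen. No size or direction of step is therefore supported beyond the scatter.

The expectation for compound 4 is accordingly an unchanged number, a 1.0-fold higher number from compound 1 to compound 4 (0.01 log units; within the scatter), with a wide range to reflect the absence of relevant steps. The estimate for compound 4 is 40000 nM, between 10000 nM and 100000 nM.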

Compound 4, concentration for 50% growth inhibition: > 80000 nM
Compound 4 ended at the assay's limit; the forecaster's own chance of this, stated with the estimate: 35%; middle value at least 2.0-fold (0.30 log units) away from the limit.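

In this assay, compound 4 gives only a limit of the assay: the limit of > 80000 nM in this assay, at which 1 of the 4 values shown sits.

Going by these compounds alone, this is the first reading at the nitrogen of the shared core, where acetyl in place of hydrogen gives an at least 2.0-fold higher number from compound 1 to compound 4 (0.30 log units; that floor lies within the scatter). The change therefore brings no gain in growth inhibition on the trifluoromethyl anilide, but the floor of this step lies within the scatter, so the data do not establish a real loss, and any loss has no measured size.

As far as these compounds go, whether this outcome belongs to acetyl alone or to any replacement of that hydrogen stays open, and a methyl or a longer chain such as butanoyl on the same nitrogen would separate the two. Also open, from the compounds shown here alone, is whether acetyl at this nitrogen would act in the same way on the hydroxy anilide compound 3.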